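The source may hold more compounds than are shown below. What is called first, only, known or untested is meant among the compounds shown, and "the series" means these compounds.

Measured so far in a functional assay on HL-60 cells (Homo sapiens) for inhibition (a lower number here means a stronger inhibitor, a higher number a weaker inhibitor), as follows
compound 1 `COc1cc(/C=C\c2cn(C(C)=O)c3ccccc23)cc(OC)c1OC` gives 2850 nM
compound 2 `COc1cc(/C=C/c2cn(C)c3ccccc23)cc(OC)c1OC` gives 3090 nM

Compound 2 stands level with compound 1 within the scatter, so neither leads on these numbers. Next in line is compound 3 `COc1cc(/C=C\c2cn(C)c3ccccc23)cc(OC)c1OC`, and its change from compound 2 is confined to one feature (the two compounds have the same atoms and bonds and differ only in configuration as drawn: 1 of 1 stereo elements differ; a double bond is drawn E in compound 2 and Z in compound 3). Among the compounds with values here, no measured pair isolates this change, since compound 1 and compound 2 differ in more than one place. Compound 3 has the double bond drawn Z, as does compound 1, and the value of compound 1 (2850 nM) is the only reference for that configuration, though a weak one. A modest move is therefore expected, and no change beyond the scatter would be no surprise. The expected move is a 2.6-fold lower number from compound 2 to compound 3 (0.41 log units; beyond the scatter) toward a stronger inhibitor. Compound 3 is estimated at 1200 nM (expected range 150 nM to 6000 nM).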

Compound 3, half-maximal inhibitory concentration: 3090 nM
Compound 3: the middle estimate sits 2.6-fold (0.41 log units) below what was measured; the measured number falls inside the stated range.
By their numbers in this assay, from the lowest: compounds 1, 2 and 3 (each within the scatter of the next).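

In this assay the step is no change at the digits printed from compound 2 to compound 3 (within the scatter), so with methyl on the aromatic nitrogen, these numbers do not separate the two drawn configurations of the double bond. With the double bond drawn Z in both compounds, methyl in place of acetyl on the aromatic nitrogen gives a 1.1-fold higher number from compound 1 to compound 3 (0.04 log units; within the scatter), so this change also shows no effect that can be read beyond the scatter. The first of these steps is a direct reading of configuration alone, with nothing else varying: the fact that compounds 2 and 3 differ only in the configuration as drawn

From the compounds shown here alone, the reading of configuration holds only for compounds with methyl on the aromatic nitrogen, and whether it carries over to acetyl there stays open. Also open, going by these compounds, is how a longer chain or an amine on the aromatic nitrogen, or a hydroxyl in place of a methoxy group, would read in this assay.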